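Swapping the aryl group on a propanamide chain

A few compounds are considered here, and "the series" means these few. Any claim that something is new, unique, unknown or untested is made for them only; others in the source may bear on it.

Measured compounds:
compound 1 `O=C(CCc1ccccc1)Nc1nc2ccccc2c(=O)s1` 17.6 nM
compound 2 `COc1cccc(CCC(=O)Nc2nc3ccccc3c(=O)s2)c1` 95.3 nM
compound 3 `COc1cccc(/C=C/CC(=O)Nc2nc3ccccc3c(=O)s2)c1` 238 nM

In an in vitro assay on cells for inhibition of Amine oxidase [flavin-containing] B (Homo sapiens), read by fluorescence and Amplex Red, with stated times of 30 min and 45 min (a higher number here means a weaker inhibitor, a lower number a stronger inhibitor), compound 2 gives 95.3 nM, the second highest of the three numbers; compound 3 gives 238 nM and compound 1 gives 17.6 nM. Among the compounds with values here, the only step that differs in one place, a 5.4-fold higher number from compound 1 to compound 2 (0.73 log units; beyond the scatter), arose from a methoxy in place of hydrogen on an aromatic carbon. Compound 4 `O=C(CCc1ccccc1Br)Nc1nc2ccccc2c(=O)s1` differs from compound 2 by 2-bromophenyl in place of 3-methoxyphenyl on a saturated chain carbon, two bonds along the chain from a carbonyl carbon. Within the data shown here, the methoxy that accompanied the weaker number of compound 2 is gone, yet no measured step tells what a bromine on the ring does, so the expectation rests on compound 1 alone. Compound 4 is therefore expected to give 40 nM in this assay, between 12 nM and 130 nM, an estimated 2.4-fold lower number from compound 2 to compound 4 (0.38 log units; beyond the scatter).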

Compound 4, half-maximal inhibitory concentration: 2.09 nM
For compound 4 the middle estimate is 19-fold (1.28 log units) above the measured one; measured number outside the range, below it.
By their numbers in this assay, from the lowest: compound 4; then compound 1; then compound 2; then compound 3.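

In this assay, the aryl group on this chain can carry a substituent with a gain: bromo in place of hydrogen on an aromatic carbon brings an 8.4-fold lower number from compound 1 to compound 4 (0.93 log units; beyond the scatter) and thus runs opposite to methoxy in place of hydrogen, which brought a 5.4-fold higher number from compound 1 to compound 2 (0.73 log units; beyond the scatter). Replacing 3-methoxyphenyl with 2-bromophenyl brings a 46-fold lower number from compound 2 to compound 4 (1.66 log units; beyond the scatter) and changes both the substituent and its place on the ring. No evidence bears on the reason for this result. From the compounds shown here alone, whether the gain belongs to bromine itself or to its place remains open. A 3-bromophenyl or a 2-methoxyphenyl group on the same chain would separate the two.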